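Difluoromethoxy in Place of Methoxy on the Sulfonamide Aryl

The source may report more compounds than this note shows. Statements on the series, on what has been measured and on what is new or still open speak of the compounds shown alone.

Compound 1, `CCc1ccccc1NS(=O)(=O)c1ccc(N2CCNC2=O)cc1`: 180 nM
Compound 2, `COc1ccc(NS(=O)(=O)c2ccc(N3CCNC3=O)cc2)cc1`: 580 nM
Compound 3, `Cc1ccccc1NS(=O)(=O)c1ccc(N2CCNC2=O)cc1`: 150 nM

The three measured compounds share one core and differ only in the aryl group on the sulfonamide nitrogen. In a functional assay on M21 cells (Homo sapiens) for antiproliferative activity, read by sulforhodamine B assay, with a stated time of 48 h (a lower number here means a stronger inhibitor, a higher number a weaker inhibitor), compound 2 gives 580 nM, the highest number of the three. Both steps away from it, a 3.9-fold lower number from compound 2 to compound 3 (0.59 log units; beyond the scatter) and the reverse of a 3.2-fold higher number from compound 1 to compound 2 (0.51 log units; beyond the scatter), lie beyond the scatter, so compound 2 is the weakest inhibitor of this small set. Compound 1 and compound 3 sit within the scatter of each other, as a 1.2-fold lower number from compound 1 to compound 3 (0.08 log units; within the scatter) shows.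

Compound 4, `O=C1NCCN1c1ccc(S(=O)(=O)Nc2ccc(OC(F)F)cc2)cc1`, keeps the aryl group of compound 2 and alters it in one place: difluoromethyl in place of methyl on an oxygen on an aromatic ring. Among the measured compounds shown here, no measured step touches the substituent on this oxygen. The two steps beyond the scatter exchange the entire aryl group, whereas a 1.2-fold lower number from compound 1 to compound 3 (0.08 log units; within the scatter) shows that a small change on the aryl ring can stay within the scatter. A change confined to the group on the oxygen is therefore expected to move the number little, in either direction. Compound 4 is expected to give 450 nM, with a range from 200 nM to 1100 nM. The expected step of a 1.3-fold lower number from compound 2 to compound 4 (0.11 log units; within the scatter) lies within the scatter.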

Compound 4, half-maximal inhibitory concentration: 410 nM
Compound 4: the middle estimate sits 1.1-fold (0.04 log units) above what was measured, and the stated range covers the measured number.
By their numbers in this assay, from the lowest: compounds 3 and 1 (each within the scatter of the next); then compounds 4 and 2 (each within the scatter of the next).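

In this assay, among the compounds shown here, the step of a 1.4-fold lower number from compound 2 to compound 4 (0.15 log units; within the scatter) is the first measured change confined to the group on the oxygen on an aromatic ring, and it stays within the scatter. The earlier steps shown here beyond the scatter exchanged the entire aryl group on the sulfonamide nitrogen, whereas this pair shows that methoxy can give way to difluoromethoxy with the rest of that aryl group held fixed and without a shift that can be told from repeat measurement, so the two compounds cannot be ranked against each other. No measurement at hand bears on why the number holds across this change, and the pair alone gives no account of it.

What the compounds shown leave open is whether this position stays as undemanding with a group of another kind on the oxygen, such as a longer chain like propyl or a trifluoromethyl group, or with an amine or a carboxylic acid in place of the methoxy. They also leave open whether the oxygen itself matters, since every comparison at this position keeps it in place.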